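A hydroxyphenyl in place of furan on the hydrazone

This account rests on a few compounds, and the source may have more. Where it says the series, first, only, none or still open, it means among the compounds named here.

Compound 1, `C/C(=N\NC(=O)c1cccc(S(=O)(=O)N2CCOCC2)c1)c1ccc(F)cc1`, gives in a functional assay on EC9706 cells (Homo sapiens) for antiproliferative activity, read by MTT assay, with a stated time of 72 h (on this read-out lower numbers stand for stronger inhibition and higher numbers for weaker inhibition), the limit > 100000 nM.
Compound 2, `C/C(=N\NC(=O)c1cccc(S(=O)(=O)N2CCOCC2)c1)c1cc(F)ccc1O`, gives in this assay a value of 2210 nM.
Compound 3, `O=C(N/N=C/c1ccco1)c1cccc(S(=O)(=O)N2CCOCC2)c1`, gives in this assay the limit > 100000 nM.

Compound 3 thus stands at a limit and not at a number, as do two of the three values shown: the limit of > 100000 nM in this assay, at which 2 of the 3 values shown sit. Compound 4, `COc1ccc(/C=N/NC(=O)c2cccc(S(=O)(=O)N3CCOCC3)c2)c(O)c1`, is not yet measured. It differs from compound 3 in one place: 2-hydroxy-4-methoxyphenyl in place of furan-2-yl on a carbon with a double bond to nitrogen. Among the measured compounds shown here, only one measured step bears on this, and it is related rather than identical: an at least 45-fold lower number from compound 1 to compound 2 (1.65 log units; beyond the scatter). There too a phenyl bearing a hydroxyl entered on the carbon with a double bond to nitrogen, and the number moved from a limit into the measurable range. Compound 3 and compound 4 carry hydrogen rather than methyl on that carbon, and the group leaving is a furan rather than a phenyl, so the parallel is loose. A large step in the direction of stronger inhibition is nevertheless expected, with a real chance that only a limit is reported again. For compound 4 the estimate is 6000 nM, from 1200 nM to 60000 nM. The step expected from compound 3 is an at least 16-fold lower number from compound 3 to compound 4 (1.22 log units; beyond the scatter).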

Compound 4, half-maximal inhibitory concentration: 1090 nM
Beside the measured number, compound 4's estimate is 5.5-fold (0.74 log units) above it; the measured number lies below the stated range.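

In this assay, the step to the hydroxyl-bearing ring, an at least 91-fold lower number from compound 3 to compound 4 (1.96 log units; beyond the scatter), shows that a large change at this place is not confined to compounds with methyl on the carbon with a double bond to nitrogen: here that carbon carries hydrogen. It also shows that such a change can start from a furan-2-yl as well as from a 4-fluorophenyl, and that the ring entering need not carry fluorine. The two compounds that stay at a limit of the assay are the two without a hydroxyl on the ring at this place: the limit of > 100000 nM in this assay, at which 2 of the 4 values shown sit.

Going by these compounds, the phenyl ring, hydroxyl and methoxy all enter together, and which of them carries the change stays open. The compounds shown also leave open how an amine or a carboxylic acid in place of the hydroxyl would read.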